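Removing the Ring Methyl Group: Expected Half-Life of Compound 3

The source may report more compounds than this note shows. Statements on the series, on what has been measured and on what is new or still open speak of the compounds shown alone.

Measured compounds:
compound 1 `Cc1cccc(CSc2cc(Cl)c(C)cc2S(=O)(=O)/N=C(\N)n2nccc2-c2ccccc2)c1`: 0.232 h
compound 2 `Cc1cc(S(=O)(=O)/N=C(\N)n2nccc2-c2ccccc2)c(SCc2ccccc2C)cc1Cl`: 0.0802 h

Within the data shown here, in an ADME assay on microsomes from liver (Homo sapiens) for metabolic stability, read by LC-MS, using NADPH, tested at 5 uM (on this read-out higher numbers stand for a longer-lived compound and lower numbers for a shorter-lived compound), compound 2 gives the lowest of the two numbers measured so far. Among the measured compounds shown here, the only measured step is a 2.9-fold lower number from compound 1 to compound 2 (0.46 log units; beyond the scatter), which moved the methyl group from one position of the benzyl ring to another, and compound 2 was the shorter-lived of the pair.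

Compound 3 `Cc1cc(S(=O)(=O)/N=C(\N)n2nccc2-c2ccccc2)c(SCc2ccccc2)cc1Cl` takes a different route: hydrogen in place of methyl on an aromatic carbon. For the measured compounds named here, no measured step removes a methyl group outright, so the one step on hand bears only loosely on this change. Since moving the methyl within the same ring shifted the number by a modest amount, taking it away is expected to shift it by no more than that, most likely upward, back toward compound 1. The step of a 1.6-fold higher number from compound 2 to compound 3 (0.21 log units; within the scatter) is therefore expected to be small and may fall within the scatter. For compound 3 the estimated value is 0.13 h, within a range of 0.06 h to 0.3 h.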

Compound 3, half-life: 0.0772 h
Compound 3: middle estimate off by 1.7-fold (0.23 log units), on the high side; the measured number falls inside the stated range.
By their numbers in this assay, from the lowest: compounds 3 and 2 (each within the scatter of the next); then compound 1.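

In this assay, taking the methyl off the 2-methylbenzyl group to give the benzyl group leaves the half-life within the scatter (a 1.0-fold lower number from compound 2 to compound 3 (0.02 log units; within the scatter)), so at this place on the ring the methyl makes no readable difference. Compound 3 also stays well short of compound 1 (a 3.0-fold lower number from compound 1 to compound 3 (0.48 log units; beyond the scatter)), so of these three compounds only compound 1, with its 3-methylphenyl group, stands apart, with a longer half-life. No measurement offered here explains why the methyl counts in one place and not in the other.

Still open, going by these compounds, is whether the longer half-life of compound 1 depends on the methyl itself or whether another group on this ring, such as a methoxy or a fluorine, would give the same result. The effect of a longer chain in place of the benzyl carbon is also unknown.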